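The source may hold more compounds than are shown below. What is called first, only, known or untested is meant among the compounds shown, and "the series" means these compounds.

Compound 2 `O=C(CCC1CCCCC1)Nc1ncc(Cc2ccccc2)s1`: in an ADME assay on P388D1 cells (Mus musculus) for cytotoxicity, read by fluorescence and resazurin assay, with a stated time of 72 h (on this read-out higher numbers stand for weaker inhibition and lower numbers for stronger inhibition), compound 2 gives > 40000 nM, which is a limit of the assay rather than a number.
Compound 3 `O=C(Nc1ncc(Cc2cccc3nsnc23)s1)C1CCCCC1`: in this assay compound 3 gives > 40000 nM, again a limit and not a number.
Compound 1 `O=C(Nc1ncc(Cc2cccc3c2CCCC3)s1)C1CCCCC1`: in this assay compound 1 gives "not determined" (no result reported), so no result for it was reported.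

Compound 2 thus stands at the limit of > 40000 nM in this assay, at which 2 of the 3 values shown sit, and compound 3 sits at the same limit; nothing separates them on the numbers shown. The piece follows the step from compound 2 to compound 4 `O=C(CCC1CCCCC1)Nc1ncc(Cc2ccncc2)s1`, where the change is pyridin-4-yl in place of phenyl on a saturated chain carbon bound to an aromatic carbon. For the measured compounds named here, no step between two measured compounds is available to lean on. The expectation is therefore that the step from compound 2 to compound 4 in this assay brings no change beyond the scatter, and the estimated step is a number no higher from compound 2 to compound 4 (the limit leaves the size open). Compound 4 is expected at about 40000 nM, within a range from 15000 nM to 100000 nM.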

Compound 4, half-maximal inhibitory concentration: > 40000 nM
Compound 4 was reported as a limit; the forecaster's own chance of this, stated with the estimate: 75%; the middle value sits exactly at the limit.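

Compound 2 and compound 4 both give only a limit in this assay, so the step between them cannot be read. The compounds shown leave open whether pyridin-4-yl in place of phenyl changes cytotoxicity at all.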